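Trimming a tert-butyl to an ethyl on a sulfonamide aryl

The source may hold more compounds than are shown below. What is called first, only, known or untested is meant among the compounds shown, and "the series" means these compounds.

Measured compounds:
compound 1 `CCc1ccc(N(CC(C)C)S(=O)(=O)c2ccc3c(c2)C(=O)CC(CC2CCOCC2)O3)cc1` — 4.53
compound 2 `CC(C)CN(Cc1ccccc1C(F)(F)F)S(=O)(=O)c1ccc2c(c1)C(=O)CC(C1CCOCC1)O2` — 4.32
compound 3 `CC(C)CN(c1ccc(C(C)(C)C)cc1)S(=O)(=O)c1ccc2c(c1)C(=O)CC(C1CCOCC1)O2` — 4.97

In a physicochemical assay for lipophilicity, at pH 7.4 (on this read-out higher numbers stand for higher lipophilicity and lower numbers for lower lipophilicity), compound 3 gives 4.97, the highest of the three numbers; compound 1 lies nearest and compound 2 furthest. Among the measured compounds shown here, the one step recorded between measured compounds, a number 0.65 log units higher from compound 2 to compound 3 (beyond the scatter), replaces the whole group on the sulfonamide nitrogen and so bears only loosely on the change at hand. Compound 4 `CCc1ccc(N(CC(C)C)S(=O)(=O)c2ccc3c(c2)C(=O)CC(C2CCOCC2)O3)cc1` keeps the core of compound 3 and differs from it in one place: ethyl in place of tert-butyl on an aromatic carbon. For the measured compounds named here, no measured step isolates this change. Compound 4 shares its 4-ethylphenyl group with compound 1 but differs from it elsewhere, so the value of compound 1, 4.53, is only a rough anchor. Cutting two carbons from the group should lower the number beyond the scatter, and compound 4 is therefore expected to give a step of a number 0.82 log units lower from compound 3 to compound 4 (beyond the scatter). For compound 4 the estimate is 4.15, within a range from 3.75 to 4.55.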

Compound 4, distribution coefficient: 4.21
Compound 4: middle estimate off by 0.06 log units, on the low side; low and high end bracket the measured number.
By their numbers in this assay, from the lowest: compounds 4, 2 and 1 (each within the scatter of the next, the first and the last beyond it); then compound 3.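

In this assay, the change from tert-butyl to ethyl on an aromatic carbon is now isolated at this position, para to a large group: a number 0.76 log units lower from compound 3 to compound 4 (beyond the scatter). With the ethyl in place, swapping the whole group on the sulfonamide nitrogen no longer separates the numbers, giving a number 0.11 log units lower from compound 2 to compound 4 (within the scatter), whereas with the tert-butyl the comparison gave a number 0.65 log units higher from compound 2 to compound 3 (beyond the scatter). Compound 4 also shows that a change away from this position registers in this read-out, with oxan-4-yl in place of (oxan-4-yl)methyl on a saturated ring carbon giving a number 0.32 log units lower from compound 1 to compound 4 (beyond the scatter).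

No evidence at hand accounts for any of these steps. As far as these compounds go, how a methyl, a methoxy group or an amine on the same aromatic carbon would read in this assay remains open, as does whether the size of the tert-butyl to ethyl step would hold with (oxan-4-yl)methyl on the core.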